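Swapping Chloro for Bromo on the Ring Double Bond

This account rests on a few compounds, and the source may have more. Where it says the series, first, only, none or still open, it means among the compounds named here.

Compound 1 `Cc1ccc(S(=O)(=O)N2CCC(Cl)=CC2CC(C)C)cc1`: 35000 nM
Compound 2 `CCCCCCCC1C=C(Cl)CCN1S(=O)(=O)c1ccc(C)cc1`: 92000 nM
Compound 3 `Cc1ccc(S(=O)(=O)N2CCC(Cl)=CC2C2CCCCC2)cc1`: 39000 nM

Of the compounds shown here, three sharing one core have been tested in a functional assay on A2780 cells (Homo sapiens) for antiproliferative activity, read by sulforhodamine B assay, with a stated time of 48 h; on this read-out higher numbers stand for weaker inhibition of growth and lower numbers for stronger inhibition of growth. Compound 1 gives 35000 nM, the lowest of the three numbers, but compound 3 sits within the scatter of it (a 1.1-fold higher number from compound 1 to compound 3 (0.05 log units; within the scatter)), so the two cannot be told apart. Compound 2 is the furthest away (a 2.6-fold higher number from compound 1 to compound 2 (0.42 log units; beyond the scatter)), and the remaining step (a 2.4-fold lower number from compound 2 to compound 3 (0.37 log units; beyond the scatter)) runs the other way. All three measured steps change only the side chain on the saturated ring carbon.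

Compound 4 `Cc1ccc(S(=O)(=O)N2CCC(Br)=CC2CC(C)C)cc1` differs from compound 1 in a different place: bromo in place of chloro on a double-bonded ring carbon. Among the measured compounds shown here, no measured step touches this double-bonded ring carbon or its halogen, so none of them bears directly on the change. With nothing pointing either way, the expectation is a step no larger than the scatter in this assay, in no particular direction. Compound 4 is therefore expected to land near 35000 nM, somewhere between 15000 nM and 80000 nM. The step this estimate implies, no change at the digits printed from compound 1 to compound 4 (within the scatter), is expected to stay within the scatter.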

Compound 4, concentration for 50% growth inhibition: 36000 nM
Compound 4: middle estimate off by 1.0-fold (0.01 log units), on the low side, within the range that was stated.
By their numbers in this assay, from the lowest: compounds 1, 4 and 3 (each within the scatter of the next); then compound 2.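

In this assay, putting bromo in place of chloro on the double-bonded ring carbon gives a 1.0-fold higher number from compound 1 to compound 4 (0.01 log units; within the scatter), so with the isobutyl group in place these two halogens cannot be told apart. Among the compounds shown here, this is the first reading at this position, as the earlier steps changed only the side chain on the saturated ring carbon. No measurement shown here offers an explanation for this result.

Going by these compounds, it remains open whether a different kind of group on this double-bonded ring carbon, such as an amine, a nitrile or a methyl group, would shift the number beyond the scatter. On these data alone, it is also open whether bromo and chloro would remain indistinguishable alongside the longer chain of compound 2 or the cyclohexyl group of compound 3.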